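From 3-chlorophenyl to 4-fluorophenyl: an expected small step

The compounds below may be only part of what the source reports. "The series", "measured", "known", "first", "only" and "open" are said of these compounds alone.

In a functional assay on M21 cells (Homo sapiens) for antiproliferative activity, read by sulforhodamine B assay, with a stated time of 48 h (a higher number here means a weaker inhibitor, a lower number a stronger inhibitor), compound 1 (`Cc1cccc(OS(=O)(=O)c2ccc(N3CCN(C)C3=O)cc2)c1`) gives 2300 nM and compound 2 (`CN1CCN(c2ccc(S(=O)(=O)Oc3cccc(Cl)c3)cc2)C1=O`) gives 1600 nM. Going by the values given here, the two values stand within the scatter of each other, so compound 2 is effectively level with its only measured neighbour. Compound 3 (`CN1CCN(c2ccc(S(=O)(=O)Oc3ccc(F)cc3)cc2)C1=O`) has 4-fluorophenyl in place of 3-chlorophenyl on an oxygen. Among the compounds with values here, the only measured step, a 1.4-fold lower number from compound 1 to compound 2 (0.16 log units; within the scatter), came with chloro in place of methyl on an aromatic carbon. Within the data shown here, it bears on this change only loosely, and no measured compound carries the 4-fluorophenyl group. A small expected move toward a higher number is therefore all that can be offered, with wide margins. The expected step is a 1.9-fold higher number from compound 2 to compound 3 (0.27 log units; within the scatter). The estimate for compound 3 is 3000 nM, within an expected range of 1000 nM to 9000 nM.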

Compound 3, half-maximal inhibitory concentration: > 100000 nM
Compound 3 ended at the assay's limit; the forecaster's own chance of this, stated with the estimate: 5%; middle value at least 33-fold (1.52 log units) away from the limit.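

In this assay the value of compound 3, > 100000 nM, is a limit and not a number: the limit of > 100000 nM in this assay, at which 1 of the 3 values shown sits. Even so, 4-fluorophenyl in place of 3-chlorophenyl, on an oxygen whose other neighbour is the sulfonyl sulfur, gives an at least 62-fold higher number from compound 2 to compound 3 (1.79 log units; beyond the scatter), and 4-fluorophenyl in place of 3-methylphenyl gives an at least 43-fold higher number from compound 1 to compound 3 (1.63 log units; beyond the scatter). Chloro in place of methyl had left the number within the scatter, so the earlier pair gave no sign that this position could respond so sharply to a change of its aryl group.

From the compounds shown here alone, both the halogen and its place on the ring change in these steps, so it stays open whether 3-fluorophenyl or 4-chlorophenyl would stand with compound 2 or with compound 3. Going by these compounds, it is also open how an amine or a carboxylic acid on this ring would read in this assay.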